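The source may hold more compounds than are shown below. What is called first, only, known or untested is meant among the compounds shown, and "the series" means these compounds.

Of the compounds shown here, three sharing one core have been measured in an assay on CHO cells for displacement of a labelled ligand from transient receptor potential cation channel subfamily V member 1 (Homo sapiens), read by scintillation counting, with a stated time of 60 min; a lower number here means a stronger inhibitor, a higher number a weaker inhibitor. Compound 1 `CN(C)C1(Cc2ccccc2)CCN(c2cc(C(F)(F)F)ccc2CNC(=O)Nc2ccc(CO)c(F)c2)CC1` gives 27.9 nM. Compound 2 `CN(C)C1(Cc2ccccc2)CCN(c2cc(C(F)(F)F)ccc2CNC(=O)Nc2cccc3c2CC(O)CC3)CC1` gives 0.95 nM, and the step of a 29-fold lower number from compound 1 to compound 2 (1.47 log units; beyond the scatter) is the largest seen here. Compound 3 `CN(C)C1(Cc2ccccc2)CCN(c2cc(C(F)(F)F)ccc2CNC(=O)Nc2ccc3ccncc3c2)CC1` gives 7.33 nM; it stands second highest of the three numbers, with a 3.8-fold lower number from compound 1 to compound 3 (0.58 log units; beyond the scatter) placing it below compound 1 and a 7.7-fold higher number from compound 2 to compound 3 (0.89 log units; beyond the scatter) placing it above compound 2.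

Compound 4 `CN(C)C1(Cc2ccccc2)CCN(c2cc(C(F)(F)F)ccc2CNC(=O)Nc2ccc3cnccc3c2)CC1` is built from compound 3 by the change isoquinolin-6-yl in place of isoquinolin-7-yl on an amide-type nitrogen. The two compounds have the same atoms, joined differently, so the group keeps its one hydrogen-bond acceptor and its two rings; only the point at which the amide-type nitrogen attaches to the bicyclic group moves.

Among the measured compounds shown here, no measured step here moves a group within the same ring system, so none of the three steps bears directly on this change. The steps of a 3.8-fold lower number from compound 1 to compound 3 (0.58 log units; beyond the scatter) and a 7.7-fold higher number from compound 2 to compound 3 (0.89 log units; beyond the scatter) only show that swapping the whole group on this nitrogen can shift the number modestly in either direction. Without a closer precedent, the expected step of a 1.0-fold lower number from compound 3 to compound 4 (0.02 log units; within the scatter) is small, and compound 4 is estimated at 7 nM, with a range from 2 nM to 25 nM.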

Compound 4, inhibition constant: 62 nM
Compound 4: middle estimate off by 8.9-fold (0.95 log units), on the low side; measured number above the stated range.
By their numbers in this assay, from the lowest: compound 2; then compound 3; then compound 1; then compound 4.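

In this assay, moving only the point where the amide-type nitrogen joins the bicyclic group gives an 8.5-fold higher number from compound 3 to compound 4 (0.93 log units; beyond the scatter), so with the atoms and the counted features of the group unchanged, the attachment point alone shifts the number beyond the scatter, something the earlier swaps of whole groups could not separate out. This single move also takes the isoquinoline from better than the 3-fluoro-4-(hydroxymethyl)phenyl group to worse, with a 2.2-fold higher number from compound 1 to compound 4 (0.35 log units; beyond the scatter), and compound 4 now has the highest number of the four compounds. The gap to the best group shown widens as well, with a 65-fold higher number from compound 2 to compound 4 (1.81 log units; beyond the scatter), so isoquinolin-6-yl stands much further from 3-hydroxy-1,2,3,4-tetrahydronaphthalen-5-yl than isoquinolin-7-yl does.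

Nothing shown here explains why the two attachment points differ. As far as these compounds go, it also remains open whether an amine or a hydroxymethyl group added to the isoquinolin-7-yl group would bring the number closer to that of compound 2, and whether the isoquinolin-6-yl group would respond to such an addition in the same way.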